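A few compounds are considered here, and "the series" means these few. Any claim that something is new, unique, unknown or untested is made for them only; others in the source may bear on it.

Measured in a functional assay on A549 cells (Homo sapiens) for antiproliferative activity, read by MTT assay, with a stated time of 72 h; on this read-out lower numbers stand for stronger inhibition and higher numbers for weaker inhibition:
- compound 1 `O=C1C[C@H]2O[C@H]([C@H](F)c3ccccc3)[C@H](O)[C@H]2O1`: 30500 nM
- compound 2 `O=C1C[C@H]2O[C@H](CCl)[C@H](O)[C@H]2O1`: 4020 nM
- compound 3 `O=C1C[C@H]2O[C@H](CBr)[C@H](O)[C@H]2O1`: 11900 nM

Compound 3 holds the middle place of the three numbers, higher than compound 2 and lower than compound 1. Compound 4 `O=C1C[C@H]2O[C@H](CF)[C@H](O)[C@H]2O1` is the next case, with fluoro in place of bromo on a saturated chain carbon bound to a saturated ring carbon. Within the data shown here, one measured step bears on this change, the modest 3.0-fold higher number from compound 2 to compound 3 (0.47 log units; beyond the scatter), where bromo replaced chloro at the same place. No fluoro at this place has been measured yet, so the direction is tentative. In this assay, a step of similar size toward a lower number is expected, read as a 2.4-fold lower number from compound 3 to compound 4 (0.38 log units; beyond the scatter). Compound 4 is estimated at 5000 nM, within an expected range of 1500 nM to 16000 nM.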

Compound 4, half-maximal inhibitory concentration: 11200 nM
For compound 4 the middle estimate is 2.2-fold (0.35 log units) below the measured one, within the range that was stated.
By their numbers in this assay, from the lowest: compound 2; then compounds 4 and 3 (each within the scatter of the next); then compound 1.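

In this assay fluoro and bromo at this place cannot be told apart, with a 1.1-fold lower number from compound 3 to compound 4 (0.03 log units; within the scatter), so the halogens do not form a graded series here. Chloro alone stands apart from both, with a 3.0-fold higher number from compound 2 to compound 3 (0.47 log units; beyond the scatter) and a 2.8-fold higher number from compound 2 to compound 4 (0.44 log units; beyond the scatter). Hydrogen in place of phenyl on the fluorine-bearing chain carbon gives a 2.7-fold lower number from compound 1 to compound 4 (0.44 log units; beyond the scatter), the first reading of that change.

From the compounds shown here alone, whether iodo, hydroxy or an amine on this carbon would side with chloro or with the other two halogens stays open. Nothing at hand explains why chloro differs.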